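Methyl in place of hydrogen: half-life notes at low pH

The compounds below may be only part of what the source reports. "The series", "measured", "known", "first", "only" and "open" are said of these compounds alone.

Measured so far in an ADME assay, at pH 3; on this read-out higher numbers stand for a longer-lived compound and lower numbers for a shorter-lived compound:
compound 1 `COc1c(C)cnc(C[S+]([O-])c2nc3cc(OC(F)F)ccc3[nH]2)c1C` gives 0.2 h
compound 2 `COc1ccnc(C[S+]([O-])c2nc3cc(OC(F)F)ccc3[nH]2)c1C` gives 0.0833 h
compound 3 `COc1ccnc(C[S+]([O-])c2nc3cc(OC(F)(F)C(F)F)ccc3[nH]2)c1` gives 0.167 h

Compound 2 and compound 1 differ by methyl in place of hydrogen on an aromatic carbon, and the step is a 2.4-fold higher number from compound 2 to compound 1 (0.38 log units; beyond the scatter). Compound 3 stands nearest to compound 1 and furthest from compound 2, and both of those gaps lie within the scatter. The difference between the core of compound 2 and the core of compound 3 is not broken down here.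

Compound 4 `COc1ccnc(C[S+]([O-])c2nc3cc(OC(F)(F)C(F)F)ccc3[nH]2)c1C`, not yet measured, differs from compound 3 by methyl in place of hydrogen on an aromatic carbon. This is the same kind of change as that from compound 2 to compound 1, though the surroundings are not identical: in compound 4 the entering methyl sits ortho to a large group as well as ortho to a methoxy group, whereas in compound 1 it sits meta to a methyl group and para to a large group. The change occurs twice among these compounds. Going by the values given here, for compound 4 in this assay a step of a 2.1-fold higher number from compound 3 to compound 4 (0.32 log units; beyond the scatter) is expected, resting on the one measured step of a 2.4-fold higher number from compound 2 to compound 1 (0.38 log units; beyond the scatter) with some allowance for the different surroundings. Compound 4 is estimated at 0.35 h, within 0.17 h to 0.7 h.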

Compound 4, half-life: 0.0833 h
Beside the measured number, compound 4's estimate is 4.2-fold (0.62 log units) above it; the measured number lies below the stated range.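

In this assay methyl in place of hydrogen on an aromatic carbon does not carry over as one fixed step from one core to the other: the same change on two cores in this assay, a 2.4-fold higher number (0.38 log units; beyond the scatter) from compound 2 to compound 1 and a 2.0-fold lower number (0.30 log units; within the scatter) from compound 3 to compound 4, 4.8-fold (0.68 log units) apart, beyond the scatter of two such steps
Going by these compounds alone, the step reads a 2.0-fold lower number from compound 3 to compound 4 (0.30 log units; within the scatter) on the core of compound 3, so no effect of the methyl is resolved there, and a 2.4-fold higher number from compound 2 to compound 1 (0.38 log units; beyond the scatter) remains the only step of this kind beyond the scatter. The two steps differ both in the core and in where the methyl enters, so these compounds do not show which of the two differences accounts for the gap, and with one pair on each core they give no general rule. Difluoromethyl in place of hydrogen on the chain carbon gives no change at the digits printed from compound 2 to compound 4 (within the scatter) in these compounds.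

Still open, from the compounds shown here alone, is whether the methyl step on the core of compound 3 would stand apart from the scatter on repeated measurement. Also open, going by these compounds, is how another group on the same aromatic carbon, such as ethyl or a chlorine atom, would behave on either core.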